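The source may hold more compounds than are shown below. What is called first, only, known or untested is meant among the compounds shown, and "the series" means these compounds.

Compound 1 `O=C(CCCN1C(=O)c2ccccc2C1=O)Nc1ccc(Cl)cc1` gives 100 mg/kg in a functional assay on the whole organism (strain albino) with Mus musculus as the target, with a stated time of 0.5 h; on this read-out higher numbers stand for an effect only at larger amounts of compound and lower numbers for an effect already at smaller amounts.
Compound 2 `O=C(CCCN1C(=O)c2ccccc2C1=O)Nc1ccc(Cl)cc1Cl` gives 300 mg/kg in this assay.

For the measured compounds named here, compound 2 stands highest of the two numbers measured so far in this assay; the one measured step, a 3.0-fold higher number from compound 1 to compound 2 (0.48 log units; beyond the scatter), lies beyond the scatter. Compound 3 `O=C(CCCN1C(=O)c2ccccc2C1=O)Nc1ccc(F)cc1F` differs from compound 2 by 2,4-difluorophenyl in place of 2,4-dichlorophenyl on an amide-type nitrogen. Going by the values given here, no measured step covers such an exchange; the step from compound 1 to compound 2 bears on it only loosely, and it was modest. For compound 3 a step of a 2.0-fold lower number from compound 2 to compound 3 (0.30 log units; within the scatter) is therefore expected. Compound 3 is estimated at 150 mg/kg in this assay, within 50 mg/kg to 400 mg/kg.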

Compound 3, minimum effective dose: 100 mg/kg
Compound 3: the middle estimate sits 1.5-fold (0.18 log units) above what was measured; the range from low to high includes it.
By their numbers in this assay, from the lowest: compounds 1 and 3 (each within the scatter of the next); then compound 2.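

In this assay the exchange of 2,4-dichlorophenyl for 2,4-difluorophenyl on the amide-type nitrogen gives a 3.0-fold lower number from compound 2 to compound 3 (0.48 log units; beyond the scatter), so this position responds to which halogen it carries and not only to added chloro. Exchanging 4-chlorophenyl for 2,4-difluorophenyl gives no change at the digits printed from compound 1 to compound 3 (within the scatter), so two halogens on the ring do not by themselves go with the higher number of compound 2. Nothing here gives a reason for either step. Going by these compounds, what an amine or a methoxy group would do in place of the halogens remains open, as does the effect of a longer chain in the shared core.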